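The source may hold more compounds than are shown below. What is called first, only, known or untested is meant among the compounds shown, and "the series" means these compounds.

Compound 1 `CCN(CC)CCCC(C)/N=C(/N)NC(=O)c1cccc(F)c1OCc1cc(Br)ccc1OC` gives 900 nM.
Compound 2 `COc1ccc(Br)cc1CCc1c(F)cccc1C(=O)/N=C(\N)NCCCN1CCCCC1` gives 3.2 nM.
Compound 3 `COc1ccc(Br)cc1CCc1c(F)cccc1C(=O)/N=C(\N)NCCCCN1CCCCC1` gives 0.58 nM.

In an assay for binding affinity to Melanocortin receptor 4 (Homo sapiens) (on this read-out higher numbers stand for weaker inhibition and lower numbers for stronger inhibition), compound 3 holds the lowest of the three numbers, with compound 2 the nearest to it and compound 1 far behind. Among the measured compounds shown here, the only step between two compounds that differ in a single place, a 5.5-fold lower number from compound 2 to compound 3 (0.74 log units; beyond the scatter), shows that lengthening the chain that carries the ring amine by one carbon already shifts the number clearly. Compound 4 `COc1ccc(Br)cc1CCc1c(F)cccc1C(=O)/N=C(\N)NCC(C)C` differs from compound 3 by isopropyl in place of 3-(piperidin-1-yl)propyl on a saturated chain carbon bound to an amine nitrogen, so the ring amine and the chain that carries it are removed altogether and only a short branched alkyl remains. For the measured compounds named here, no measured step removes that ring amine outright; the one step that touches this region, a 5.5-fold lower number from compound 2 to compound 3 (0.74 log units; beyond the scatter), only moves it, yet it stands beyond the scatter, so taking it away is expected to cost much more. Compound 1, with a different link to the outer ring and a different amine, shows 900 nM and gives no direct comparison. A large rise in this assay is therefore expected: compound 4 is estimated at 200 nM, within 20 nM to 3000 nM. The expected step is a 340-fold higher number from compound 3 to compound 4 (2.54 log units; beyond the scatter).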

Compound 4, inhibition constant: 770 nM
Compound 4: middle estimate off by 3.9-fold (0.59 log units), on the low side; the measured number falls inside the stated range.
By their numbers in this assay, from the lowest: compound 3; then compound 2; then compounds 4 and 1 (each within the scatter of the next).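

In this assay, among the compounds shown here, the earlier compounds showed only a shift in the length of the chain carrying the piperidin-1-yl ring, whereas removing that ring and its chain altogether gives a 1300-fold higher number from compound 3 to compound 4 (3.12 log units; beyond the scatter) and so counts as a large step, against the modest 5.5-fold lower number from compound 2 to compound 3 (0.74 log units; beyond the scatter) seen on lengthening. The shorter chain shows a loss of the same kind, with isopropyl in place of 2-(piperidin-1-yl)ethyl giving a 240-fold higher number from compound 2 to compound 4 (2.38 log units; beyond the scatter) and so a large step from either of the two chains, which means that the low numbers of compound 2 and compound 3 are lost with this part of the molecule on a shared core. Nothing measured here accounts for the size of this rise.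

Because compound 4 loses the ring, the amine nitrogen in it and most of the chain in one change, the compounds shown do not separate what each of these contributes. A plain hexyl chain with no amine, a morpholine ring or a diethylamino group at the end of the same chain, or a still longer chain carrying the piperidin-1-yl ring would each leave that question open to test.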